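The source may report more compounds than this note shows. Statements on the series, on what has been measured and on what is new or still open speak of the compounds shown alone.

Three compounds measured in a physicochemical assay for lipophilicity, read by HPLC, measured as octanol-water partition (on this read-out higher numbers stand for higher lipophilicity and lower numbers for lower lipophilicity), share one core and differ only at one spot on the side chain. Compound 1 `O=C1O[C@@H](CO)CN1c1ccc(-n2cc(-c3ccccn3)cn2)c(F)c1` gives 1.67. Compound 3 `O=C1O[C@@H](Cn2ccnn2)CN1c1ccc(-n2cc(-c3ccccn3)cn2)c(F)c1` gives 2. Within the data shown here, compound 2 `COC(=O)CC1CCN(C[C@H]2CN(c3ccc(-n4cc(-c5ccccn5)cn4)c(F)c3)C(=O)O2)CC1` gives 1.78, which places it within the usual scatter of both compound 1 and compound 3: the step of a number 0.11 log units higher from compound 1 to compound 2 (within the scatter) and the step of a number 0.22 log units higher from compound 2 to compound 3 (within the scatter) are both small, and only the step of a number 0.33 log units higher from compound 1 to compound 3 (beyond the scatter) reaches beyond the scatter. Compound 4 `COC(=O)NC[C@H]1CN(c2ccc(-n3cc(-c4ccccn4)cn3)c(F)c2)C(=O)O1` has not yet been measured; it differs from compound 2 by (methoxycarbonyl)amino in place of 4-((methoxycarbonyl)methyl)piperidin-1-yl on a saturated chain carbon bound to a saturated ring carbon. Among the measured compounds shown here, since every exchange at this position so far has shifted this assay only modestly, a small step of a number 0.18 log units lower from compound 2 to compound 4 (within the scatter) toward a slightly lower number is expected here. Compound 4 is therefore estimated at 1.6, with a likely range from 1.2 to 2.1.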

Compound 4, partition coefficient: 2.03
For compound 4 the middle estimate is 0.43 log units below the measured one, within the range that was stated.
By their numbers in this assay, from the lowest: compounds 1, 2, 3 and 4 (each within the scatter of the next, the first and the last beyond it).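

In this assay the ring-bearing 4-((methoxycarbonyl)methyl)piperidin-1-yl gives way to the open-chain (methoxycarbonyl)amino in a number 0.25 log units higher from compound 2 to compound 4 (within the scatter) and this exchange stays inside the scatter, as does a number 0.03 log units higher from compound 3 to compound 4 (within the scatter) for a second, quite different group. Only a number 0.36 log units higher from compound 1 to compound 4 (beyond the scatter) passes beyond the scatter, so (methoxycarbonyl)amino joins 1H-1,2,3-triazol-1-yl in standing modestly clear of hydroxy, while compound 2 does not. No measured evidence explains these shifts. As far as these compounds go, how a primary amine, a carboxylic acid or a longer chain would read at this position stays open.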